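The source may report more compounds than this note shows. Statements on the series, on what has been measured and on what is new or still open speak of the compounds shown alone.

In a functional assay on HepG2 cells (Homo sapiens) for antiproliferative activity, read by MTT assay, with a stated time of 72 h (on this read-out higher numbers stand for weaker inhibition and lower numbers for stronger inhibition), compound 1 `COc1ccc(N2C(=O)COc3ccc(-c4ccc(O)cc4)cc32)cc1` gives 10800 nM, while compound 2 `COc1cccc(N2C(=O)COc3ccc(-c4cnc5ccccc5c4)cc32)c1` gives 2080 nM, the lower of the two numbers, and the gap between them lies beyond the usual scatter. These two compounds differ in more than one place, and they offer no single step to reason from. Compound 3 `Cc1ccc(N2C(=O)COc3ccc(-c4cnc5ccccc5c4)cc32)cc1` has not yet been measured. It keeps the core of compound 2 and carries one change: 4-methylphenyl in place of 3-methoxyphenyl on an amide-type nitrogen in a ring. Within the data shown here, no measured pair shows what this swap does in this assay. No step beyond the scatter is expected, in either direction. The estimated step is small, a 1.1-fold higher number from compound 2 to compound 3 (0.04 log units; within the scatter). For compound 3 the expected value is 2300 nM, with an estimated range of 800 nM to 7000 nM.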

Compound 3, half-maximal inhibitory concentration: > 40000 nM
Compound 3: only a limit was reported (the forecaster's own chance of this, stated with the estimate: 5%); middle value at least 17-fold (1.24 log units) away from the limit.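

In this assay, placing 4-methylphenyl in place of 3-methoxyphenyl on the amide-type nitrogen in a ring gives an at least 19-fold higher number from compound 2 to compound 3 (1.28 log units; beyond the scatter). The earlier compounds shown here offered no single step to read, and this one shows that activity in this assay can depend strongly on the group at this one position while the rest of compound 2 stays unchanged. The value of compound 3 is a limit of the assay and not a number, and it is the only such limit among the compounds shown: the limit of > 40000 nM in this assay, at which 1 of the 3 values shown sits.

The swap alters both the group and the place of its substituent, so the step cannot be divided between those two changes. On these data alone, it remains open how 3-methylphenyl, 4-methoxyphenyl or 3-aminophenyl would behave on this nitrogen with the rest of compound 2 kept.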